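A few compounds are considered here, and "the series" means these few. Any claim that something is new, unique, unknown or untested is made for them only; others in the source may bear on it.

Working notes on the series. Compound 2 `Nc1nc(N)c(-c2ccc(NCc3ccnc(Cl)c3)cc2)c(COCc2ccccc2)n1` gives 1.5 nM in an in vitro assay on CHOK cells for displacement of a labelled ligand from growth hormone secretagogue receptor type 1 (Homo sapiens); on this read-out higher numbers stand for weaker inhibition and lower numbers for stronger inhibition; compound 1 `CC(=O)c1ccc(CNc2ccc(-c3c(N)nc(N)nc3COCc3ccccc3)cc2)cc1` gives 1.2 nM, and the two values lie within the scatter of each other. For the measured compounds named here, the one step measured so far, a 1.3-fold higher number from compound 1 to compound 2 (0.10 log units; within the scatter), exchanges the aryl group on the saturated chain carbon bound to the ring nitrogen without a change beyond the scatter. Compound 3 `Nc1nc(N)c(-c2ccc(NCc3csc(Cl)c3)cc2)c(COCc2ccccc2)n1` makes a change at the same place: 5-chlorothiophen-3-yl in place of 2-chloropyridin-4-yl on a saturated chain carbon bound to a nitrogen on an aromatic ring. Because a 1.3-fold higher number from compound 1 to compound 2 (0.10 log units; within the scatter) stayed within the scatter, the expected step of a 1.2-fold higher number from compound 2 to compound 3 (0.08 log units; within the scatter) is none beyond the scatter. Compound 3 is therefore estimated at 1.8 nM, within 0.7 nM to 4.5 nM.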

Compound 3, half-maximal inhibitory concentration: 6.3 nM
Compound 3: middle estimate off by 3.5-fold (0.54 log units), on the low side, and the stated range ends below it.
By their numbers in this assay, from the lowest: compounds 1 and 2 (each within the scatter of the next); then compound 3.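

This position is not indifferent to the aryl group: this assay records a 4.2-fold higher number from compound 2 to compound 3 (0.62 log units; beyond the scatter) and also a 5.3-fold higher number from compound 1 to compound 3 (0.72 log units; beyond the scatter) with the five-membered ring in place of either six-membered one. For the compounds shown here, the 5-chlorothiophen-3-yl group is thus the first change here to move the number beyond the scatter, towards weaker inhibition. No measurement available bears on the reason for this rise.

The compounds shown leave open whether ring size, the sulfur or the chlorine goes with the higher number. A thiophen-3-yl group without chlorine and a plain phenyl group would help separate these.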